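Changing the Ring on the Amine Nitrogen: Expectation for Compound 4

This account rests on a few compounds, and the source may have more. Where it says the series, first, only, none or still open, it means among the compounds named here.

Compound 1 `O/N=C(\CCN1CCN(c2ccccn2)CC1)c1ccc(F)cc1`: 74%
Compound 2 `CCCO/N=C(\CCN1CCN(c2ccccn2)CC1)c1ccccc1`: 64%
Compound 3 `CCO/N=C(\CCN1CCN(c2cccc(OC)c2)CC1)c1ccccc1`: 30%

These three compounds were measured in a functional assay on HEK293 cells with D(4) dopamine receptor (Homo sapiens) as the target, read by FLIPR; on this read-out higher numbers stand for larger maximal responses and lower numbers for smaller maximal responses. Compound 3 stands lowest of the three numbers; its nearest neighbour is compound 2, whose value is higher by a gap beyond the usual scatter, and compound 1 lies further still, also beyond the scatter. Among the compounds with values here, no two of the measured compounds differ in only one place, so no single step between them can be read off directly.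

Compound 4 `CCO/N=C(\CCN1CCN(c2ncccc2C)CC1)c1ccccc1` has not been measured yet. It differs from compound 3 in one place: 3-methylpyridin-2-yl in place of 3-methoxyphenyl on an amine nitrogen in a ring. Compound 1, which bears a six-membered aromatic ring with 1 hetero atom on the amine nitrogen in a ring, gives 74%, and compound 2 with the same kind of ring there gives 64%, whereas compound 3 with the 3-methoxyphenyl gives 30%. This pattern rests on three compounds only. On that basis the step is expected to be upward and beyond the scatter, with a number 30 percentage points higher from compound 3 to compound 4 (beyond the scatter). Compound 4 is estimated to reach 60% in this assay, within a range from 35% to 85%.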

Compound 4, largest response reached (reported as efficacy), in percent of the reference or control that the assay uses: 49%
Beside the measured number, compound 4's estimate is 11 percentage points above it; the range from low to high includes it.
By their numbers in this assay, from the lowest: compound 3; then compound 4; then compounds 2 and 1 (each within the scatter of the next).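

In this assay, within the data shown here, putting 3-methylpyridin-2-yl in place of 3-methoxyphenyl on the amine nitrogen in the ring gives the first direct reading at this position: a number 19 percentage points higher from compound 3 to compound 4 (beyond the scatter). So the maximal response responds to what sits on this nitrogen, even though the two groups look alike in simple counts: each has one six-membered aromatic ring, 0 hydrogen-bond donors, 1 hydrogen-bond acceptor and no net charge, while the ring itself changes from carbon only to one with 1 hetero atom, and the methoxy gives way to a methyl. Nothing available here explains the rise in response.

The swap changes the ring and its substituent at once, so the step cannot be divided between them, and a 3-methylphenyl group or a plain pyridin-2-yl group at this place would be needed to tell the two contributions apart. On these data alone, it also remains open whether the same swap gives a step of similar size when the chain on the oxime oxygen is a propyl or when the phenyl ring carries a fluorine.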